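The compounds below may be only part of what the source reports. "The series", "measured", "known", "first", "only" and "open" are said of these compounds alone.

Compound 1 `C[C@@H](O[C@H]1CN2C(=O)C=C(c3ccccc3)CC2[C@@H]1c1ccc(F)cc1)c1cc(C(F)(F)F)cc(C(F)(F)F)c1`: 89.5 nM
Compound 2 `C[C@@H](O[C@H]1CN2C(=O)C=C(c3ccc(NS(C)(=O)=O)cc3)CC2[C@@H]1c1ccc(F)cc1)c1cc(C(F)(F)F)cc(C(F)(F)F)c1`: 54 nM
Compound 3 `C[C@@H](O[C@H]1CN2C(=O)C=C(c3cc[n+]([O-])cc3)CC2[C@@H]1c1ccc(F)cc1)c1cc(C(F)(F)F)cc(C(F)(F)F)c1`: 2.1 nM

These three compounds were measured in an assay on CHO cells for displacement of a labelled ligand from Substance-P receptor (Homo sapiens), in the presence of a further agent that is not named here; on this read-out higher numbers stand for weaker inhibition and lower numbers for stronger inhibition. On that read-out compound 1 stands with the highest number of the three; its nearest neighbour is compound 2, a 1.7-fold lower number from compound 1 to compound 2 (0.22 log units; within the scatter), while compound 3 lies furthest away, a 43-fold lower number from compound 1 to compound 3 (1.63 log units; beyond the scatter). Compound 2 and compound 3 differ from each other as well, a 26-fold lower number from compound 2 to compound 3 (1.41 log units; beyond the scatter).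

Compound 4 `C[C@@H](O[C@H]1CN2C(=O)C=C(C3=CCOCC3)CC2[C@@H]1c1ccc(F)cc1)c1cc(C(F)(F)F)cc(C(F)(F)F)c1` is the next compound and has not yet been measured in this assay. It differs from compound 1 in one place: a group of 6 heavy atoms (5 carbon, 1 oxygen; one six-membered non-aromatic ring with 1 hetero atom) in place of a group of 6 heavy atoms (6 carbon; one six-membered aromatic ring of carbon only), on a double-bonded ring carbon.

Two measured steps leave from compound 1 and change the same group on the same double-bonded ring carbon. One of them, a 1.7-fold lower number from compound 1 to compound 2 (0.22 log units; within the scatter), stays within the scatter; the other, a 43-fold lower number from compound 1 to compound 3 (1.63 log units; beyond the scatter), is large. Neither introduces a six-membered non-aromatic ring with one hetero atom, so the direction for compound 4 is not fixed by them. Because a 43-fold lower number from compound 1 to compound 3 (1.63 log units; beyond the scatter) shows that a group with a hetero atom at this position can bring a large fall in the number, compound 4 is expected to give a somewhat lower number than compound 1, though a smaller one than compound 3 shows. The expected step is a 2.2-fold lower number from compound 1 to compound 4 (0.35 log units; beyond the scatter). For compound 4 the estimate in this assay is 40 nM, in a range from 10 nM to 150 nM.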

Compound 4, half-maximal inhibitory concentration: 9.6 nM
Compound 4: middle estimate off by 4.2-fold (0.62 log units), on the high side, outside the stated range (below it).
By their numbers in this assay, from the lowest: compound 3; then compound 4; then compounds 2 and 1 (each within the scatter of the next).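

In this assay, among these compounds, a group with no aromatic ring at all can stand on this double-bonded ring carbon: the six-membered non-aromatic ring with 1 hetero atom, an oxygen, gives a 9.3-fold lower number from compound 1 to compound 4 (0.97 log units; beyond the scatter), a step beyond the scatter that the earlier compounds could not have predicted, since both of them keep an aromatic ring here. The same group also improves on the methanesulfonamido-bearing phenyl, with a 5.6-fold lower number from compound 2 to compound 4 (0.75 log units; beyond the scatter), so the substituted phenyl of compound 2, which stayed within the scatter of compound 1, is not the better of the two ways to change this position. A fall of this kind therefore does not require the aromatic ring with its nitrogen and oxygen found in compound 3, although that group still keeps the lowest number, with a 4.6-fold higher number from compound 3 to compound 4 (0.66 log units; beyond the scatter).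

Nothing among the data gives a cause for these steps. From the compounds shown here alone, it stays open whether the ring double bond of compound 4 matters, and whether the fully saturated ring, or a piperidine ring carrying an amine nitrogen where compound 4 has its oxygen, would hold the number at this level.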